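Aminothiazole ketones: chloro for methyl on the aniline ring

The compounds below may be only part of what the source reports. "The series", "measured", "known", "first", "only" and "open" are said of these compounds alone.

The series is followed in a functional assay on HeLa cells (Homo sapiens) for antiproliferative activity, read by cell counting, with a stated time of 2 days; on this read-out lower numbers stand for stronger inhibition and higher numbers for weaker inhibition. Of the compounds shown here, three have numbers so far. Compound 1 `Cc1ccc(Nc2nc(-n3ccnc3C)cs2)cc1` gives 530 nM. Compound 2 `Cc1ccc(Nc2nc(N)c(C(=O)c3ccccc3)s2)cc1` gives 900 nM. Compound 3 `COc1ccc(Nc2nc(N)c(C(=O)c3cc(OC)c(OC)c(OC)c3)s2)cc1` gives 560 nM. Compound 2 has the largest number of the three, but the number of compound 3 sits within the usual scatter of it, and so does the number of compound 1, so no order among the three can be read from these numbers. Within the data shown here, no pair among the measured compounds differs in a single place, so no measured step is available to calibrate the change that follows.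

Compound 4 `Nc1nc(Nc2ccc(Cl)cc2)sc1C(=O)c1ccccc1` is the next to be measured in this assay. It differs from compound 2 in one place: chloro in place of methyl on an aromatic carbon.

Among the measured compounds shown here, with no measured step of this kind anywhere, the expectation rests on compound 2 alone, with its 900 nM as the anchor. The expected step of a 1.1-fold lower number from compound 2 to compound 4 (0.05 log units; within the scatter) is small and not expected to reach beyond the scatter in either direction. Compound 4 is therefore estimated at 800 nM, with a range from 350 nM to 1800 nM.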

Compound 4, half-maximal inhibitory concentration: > 10000 nM
Compound 4 gave a limit, no number (the forecaster's own chance of this, stated with the estimate: 5%); middle value at least 12-fold (1.09 log units) away from the limit.
By their numbers in this assay, from the lowest: compounds 1, 3 and 2 (each within the scatter of the next). At a limit, above all of these: compound 4.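

In this assay, compound 4 gives only a limit, not a number, of > 10000 nM. Chloro in place of methyl, on an aromatic carbon para to a large group, gives an at least 11-fold higher number from compound 2 to compound 4 (1.04 log units; beyond the scatter), the first single-place step in the series and one that lies beyond the scatter; this position is therefore not indifferent to the change, even though the swap exchanges one heavy atom for one heavy atom and leaves the counts of hydrogen-bond donors and acceptors and the net charge unchanged. The true size of the step remains unknown, as compound 4 sits at the end of the measurable range and is the only compound there: the limit of > 10000 nM in this assay, at which 1 of the 4 values shown sits.

The compounds shown leave open whether the sensitivity belongs to chloro alone or extends to other groups at this position, such as fluoro, bromo, ethyl or an amine, or to a bare hydrogen there. They also leave open whether the same 4-methylphenyl to 4-chlorophenyl change would act alike on the trimethoxyphenyl ketone of compound 3 or on the imidazole-bearing core of compound 1.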